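A few compounds are considered here, and "the series" means these few. Any claim that something is new, unique, unknown or untested is made for them only; others in the source may bear on it.

Measured so far:
compound 1 `O=C(NCc1ccc(CNS(=O)(=O)c2cccc(C(F)(F)F)c2)cc1)c1ccc(F)cc1`: 20%
compound 2 `Cc1ccc(S(=O)(=O)NCc2ccc(CNC(=O)c3ccc(F)cc3)cc2)cc1`: 30%

For the measured compounds named here, in a functional assay on the whole organism (strain C57BL/6J) for inhibition, with Mus musculus as the target, read by mobility shift assay and paw edema, with stated times of 30 min, 74 h and 2 h, at a dose of 10 mg/kg by the intraperitoneal route (on this read-out lower numbers stand for less inhibition and higher numbers for more inhibition at the one dose given (going by the name of the read-out)), compound 2 gives 30% and stands highest of the two numbers, though the only step present, a number 10 percentage points higher from compound 1 to compound 2 (within the scatter), lies within the scatter. Compound 3 `O=C(NCc1ccc(CNS(=O)(=O)c2ccc3c(c2)CCO3)cc1)c1ccc(F)cc1` differs from compound 2 by a group of 9 heavy atoms (8 carbon, 1 oxygen; one five-membered non-aromatic ring with 1 hetero atom, one six-membered aromatic ring of carbon only) in place of a group of 7 heavy atoms (7 carbon; one six-membered aromatic ring of carbon only), on a sulfonyl sulfur. Going by the values given here, the one step that bears on this place on the sulfonyl sulfur is a number 10 percentage points higher from compound 1 to compound 2 (within the scatter), which did not exceed the scatter, so no step beyond the scatter is expected in this assay here either. Compound 3 is therefore estimated at 30%, with a range from 15% to 45%. That estimate means no change at the digits printed from compound 2 to compound 3 (within the scatter).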

Compound 3, a percentage reported as inhibition, in the whole organism at one dose (the size of the read-out at that dose, not a potency): 43%
Compound 3: the middle estimate sits 13 percentage points below what was measured; the range from low to high includes it.
By their numbers in this assay, from the lowest: compounds 1 and 2 (each within the scatter of the next); then compound 3.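

In this assay the sulfonyl sulfur position now shows steps beyond the scatter, with a number 13 percentage points higher from compound 2 to compound 3 (beyond the scatter) and a number 23 percentage points higher from compound 1 to compound 3 (beyond the scatter) on entry of the group holding a five-membered non-aromatic ring with 1 hetero atom. For the compounds shown here, the exchange of 3-(trifluoromethyl)phenyl for 4-methylphenyl had given no such step, so this position responds to at least one change of group. Nothing measured here bears on the reason for these steps.

Going by these compounds, whether the oxygen or the extra ring carries the steps stays open, and 4-methoxyphenyl on the sulfonyl sulfur would bear on that. Also open, on these data alone, is how an amine or a carboxylic acid on that phenyl ring would read out.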